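A few compounds are considered here, and "the series" means these few. Any claim that something is new, unique, unknown or untested is made for them only; others in the source may bear on it.

Measured so far:
Compound 1 `COC(=O)C1=C(C)N=C(C)/C(=C(/O)OC)C1c1cccc(NC(=O)NCCNC2CCN(c3ccccc3[N+](=O)[O-])CC2)c1` gives 2 nM in an assay on SK-N-MC cells for inhibition of Neuropeptide Y receptor type 1 (Homo sapiens); on this read-out higher numbers stand for weaker inhibition and lower numbers for stronger inhibition.
Compound 2 `COC(=O)C1=C(C)N=C(C)/C(=C(/O)OC)C1c1cccc(NC(=O)NCCNC2CCN(c3ccccc3OC(F)(F)F)CC2)c1` gives 25 nM in this assay.

Going by the values given here, compound 2 stands with the higher of the two numbers, the weaker of the two; its only neighbour is compound 1, and the one measured step, a 13-fold higher number from compound 1 to compound 2 (1.10 log units; beyond the scatter), is large. Compound 3 `COC(=O)C1=C(C)N=C(C)/C(=C(/O)OC)C1c1cccc(NC(=O)NCCNC2CCN(c3ccccc3O)CC2)c1` has not yet been measured. It differs from compound 2 in one place: hydrogen in place of trifluoromethyl on an oxygen on an aromatic ring. Among the compounds with values here, no measured step makes this same change, since the single known step, a 13-fold higher number from compound 1 to compound 2 (1.10 log units; beyond the scatter), swaps nitro for trifluoromethoxy rather than removing the trifluoromethyl from the oxygen. Within the data shown here, that step shows only that a change at this place once moved the number by a large amount, so a sizeable move for compound 3 is plausible, but its direction cannot be read from the data. The step of a 1.2-fold higher number from compound 2 to compound 3 (0.08 log units; within the scatter) is therefore expected to be small, with wide margins on either side. Compound 3 is estimated at 30 nM, in the range 5 nM to 180 nM.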

Compound 3, half-maximal inhibitory concentration: 6 nM
Estimate against measurement, compound 3: 5.0-fold (0.70 log units) above; the measured number falls inside the stated range.
By their numbers in this assay, from the lowest: compound 1; then compound 3; then compound 2.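

Removing the trifluoromethyl from the oxygen, which turns trifluoromethoxy into hydroxy, gives a 4.2-fold lower number from compound 2 to compound 3 (0.62 log units; beyond the scatter) in this assay, so the number at this place depends on what the oxygen carries and not only on having an oxygen there. Hydroxy does not fully match nitro, with a 3.0-fold higher number from compound 1 to compound 3 (0.48 log units; beyond the scatter), and the three groups now form an order that the first pair alone could not give: nitro has the lowest number, hydroxy the next and trifluoromethoxy the highest, with every gap beyond the usual scatter. Nothing measured alongside these numbers speaks to what lies behind this order.

Still open, as far as these compounds go, is where other groups on this aromatic carbon would fall in the order, for example an amine, a methoxy group or a carboxylic acid, and whether any of them would give a number as low as nitro does. All three compounds also share the same core and the same chain, so these compounds cannot tell whether the order would hold with a longer chain.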